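The source may hold more compounds than are shown below. What is called first, only, known or untested is meant among the compounds shown, and "the series" means these compounds.

Series notes, compound 2 to compound 3.

For the measured compounds named here, compound 2 `COc1ccc(-c2cc3[nH]cnc3c(C#N)n2)cc1C(F)(F)F` gives 339 nM in an assay on isolated protein for inhibition of cathepsin S (Homo sapiens), read by fluorescence; a higher number here means a weaker inhibitor, a lower number a stronger inhibitor; among the two numbers so far it is the lowest, the nearest being compound 1 `N#Cc1nc(-c2cccc(C(F)(F)F)c2)cc2[nH]cnc12` with 1050 nM in this assay. Going by the values given here, the one measured step, a 3.1-fold lower number from compound 1 to compound 2 (0.49 log units; beyond the scatter), came from the methoxy in place of hydrogen on an aromatic carbon.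

Compound 3 `N#Cc1nc(-c2ccc(OCCCO)c(C(F)(F)F)c2)cc2[nH]cnc12` carries 2-hydroxyethyl in place of hydrogen on a saturated chain carbon bound to an oxygen on an aromatic ring; cut one bond further out, the same difference reads methyl to 3-hydroxypropyl, or methoxy to 3-hydroxypropoxy. Among the compounds with values here, no measured pair tests a lengthening of this ether chain, so the only bearing step is a 3.1-fold lower number from compound 1 to compound 2 (0.49 log units; beyond the scatter), which shows that the methoxy itself gave a modest gain; what a longer chain with a hydroxyl does at this place is unknown from the data.

The expectation is therefore a small step or none beyond the scatter, with the estimate for compound 3 set at 300 nM in this assay, between 100 nM and 900 nM, which means an expected step of a 1.1-fold lower number from compound 2 to compound 3 (0.05 log units; within the scatter).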

Compound 3, half-maximal inhibitory concentration: 63 nM
The estimate for compound 3 lay 4.8-fold (0.68 log units) above the measured number, and the stated range ends above it.
By their numbers in this assay, from the lowest: compound 3; then compound 2; then compound 1.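

In this assay, the place on a saturated chain carbon bound to an oxygen on an aromatic ring accepts growth beyond the methoxy of compound 2: the change to 3-hydroxypropoxy gives a 5.4-fold lower number from compound 2 to compound 3 (0.73 log units; beyond the scatter). The earlier methoxy step, a 3.1-fold lower number from compound 1 to compound 2 (0.49 log units; beyond the scatter), therefore did not mark the limit of what a substituent on this oxygen can give, and the gain continues once the chain is extended and ends in a hydroxyl. Taken from the hydrogen on the aromatic carbon, the 3-hydroxypropoxy group gives a 17-fold lower number from compound 1 to compound 3 (1.22 log units; beyond the scatter), the only step in this short series printed as large, and no measurement at hand bears on the reason for this gain.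

As far as these compounds go, the chain extension and the hydroxyl enter together in compound 3, so their shares of the step stay open; a plain propoxy, a shorter 2-hydroxyethoxy, or an amine or a carboxylic acid at the chain end would separate them. From the compounds shown here alone, how a longer chain such as 4-hydroxybutoxy would read in this assay also stays open.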